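Working notes on compound 1 and compound 3

A few compounds are considered here, and "the series" means these few. Any claim that something is new, unique, unknown or untested is made for them only; others in the source may bear on it.

Measured so far in an ADME assay on BaF3 cells (Mus musculus) for cytotoxicity (on this read-out lower numbers stand for an effect already at smaller amounts and higher numbers for an effect only at larger amounts of compound), as follows:
- compound 1 `CN1CCN(C(=O)c2cc3c(Nc4ccc(OC(F)(F)F)cc4)ncnc3s2)CC1` gives 2690 nM 
- compound 2 `CCCn1ncc2c(Nc3ccc(OC(F)(F)F)cc3)ncnc21` gives 6600 nM 

Compound 1 holds the lower number of the two, and compound 2 stands above it by more than the usual scatter. The next case is compound 3 `O=C(c1cc2c(Nc3ccc(OC(F)(F)F)cc3)ncnc2s1)N1CCC(O)CC1` which keeps the core of compound 1 and carries 4-hydroxypiperidin-1-yl in place of 4-methylpiperazin-1-yl on a carbonyl carbon. Within the data shown here, no measured pair shows this change on its own, so the expectation has little to rest on. Only compound 1 at 2690 nM and compound 2 at 6600 nM anchor it, and the range is kept wide for that reason. A small step toward a higher number in this assay is expected, and it may not clear the usual scatter. The estimated step is a 1.5-fold higher number from compound 1 to compound 3 (0.17 log units; within the scatter) and it remains an expectation until measured. The estimate for compound 3 is 4000 nM (expected range 1500 nM to 11000 nM).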

Compound 3, half-maximal effective concentration: > 10000 nM
Compound 3: no number, only a limit; the forecaster's own chance of this, stated with the estimate: 15%; middle value at least 2.5-fold (0.39 log units) from the limit.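

In this assay, among these compounds, the group on the carbonyl carbon proves able to shift the read-out with the shared core unchanged: 4-hydroxypiperidin-1-yl in place of 4-methylpiperazin-1-yl gives an at least 3.7-fold higher number from compound 1 to compound 3 (0.57 log units; beyond the scatter), the first step that can be read at this place. For compound 3 the read-out is a limit and not a number, > 10000 nM. The direction of the step is therefore settled, while its size has only a lower bound: the limit of > 10000 nM in this assay, at which 1 of the 3 values shown sits.

The change replaces a methyl-bearing ring nitrogen with a hydroxyl-bearing ring carbon, so the compounds shown do not separate the contribution of the lost 4-methylpiperazin-1-yl from that of the added hydroxyl. Also open, going by these compounds, is where morpholin-4-yl or 4-aminopiperidin-1-yl on the same carbonyl carbon would fall in this assay, and whether either would stay close to compound 1 or reach the limit as well.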